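The source may hold more compounds than are shown below. What is called first, only, known or untested is meant among the compounds shown, and "the series" means these compounds.

Compound 3 `Cc1cccc(-c2nc3cc(C)ccc3c(=O)[nH]2)c1` is one of three analogues sharing a common core and differing only in a single substituent on the pendant aromatic ring. In a functional assay on HeLa cells (Homo sapiens) for cytotoxicity, read by MTT assay, with a stated time of 2 days (a higher number here means a weaker inhibitor, a lower number a stronger inhibitor), compound 3 gives 11200 nM, the highest of the two numbers in hand, with compound 2 `COc1cccc(-c2nc3cc(C)ccc3c(=O)[nH]2)c1` nearest at 8940 nM, a gap of a 1.3-fold higher number from compound 2 to compound 3 (0.10 log units; within the scatter). Compound 1 `Cc1ccc2c(=O)[nH]c(-c3cccc(OC(F)(F)F)c3)nc2c1` gives > 50000 nM, a limit of this assay rather than a number (the limit of > 50000 nM in this assay, at which 1 of the 3 values shown sits).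

Compound 4 `Cc1ccc2c(=O)[nH]c(-c3cccc(C(F)(F)F)c3)nc2c1` has not yet been measured. Its change from compound 3 is trifluoromethyl in place of methyl on an aromatic carbon.

Going by the values given here, two measured steps bear on this. From compound 1 to compound 3 the change of methyl in place of trifluoromethoxy on an aromatic carbon gave an at least 4.4-fold lower number from compound 1 to compound 3 (0.64 log units; beyond the scatter), and from compound 1 to compound 2 the change of methyl in place of trifluoromethyl on an oxygen gave an at least 5.5-fold lower number from compound 1 to compound 2 (0.74 log units; beyond the scatter). Both show that the fluorinated substituent at this position sits at the limit, while the small methyl or methoxy group gives a measurable number. The step to compound 4 runs the other way, toward a fluorinated group, so a higher number is expected, plausibly reaching the limit again.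

Compound 4 is therefore estimated at 30000 nM, within 9000 nM to 100000 nM, a step of a 2.7-fold higher number from compound 3 to compound 4 (0.43 log units; beyond the scatter) expected.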

Compound 4, half-maximal inhibitory concentration: > 50000 nM
Compound 4 was reported as a limit (the forecaster's own chance of this, stated with the estimate: 45%); middle value at least 1.6-fold (0.22 log units) from the limit.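

The earlier compounds shown here placed only trifluoromethoxy at the limit, so the oxygen that links it to the aromatic carbon could still have mattered, but compound 4 shows that trifluoromethyl attached directly to that carbon also reaches it. In this assay, the change from methyl gives an at least 4.4-fold higher number from compound 3 to compound 4 (0.64 log units; beyond the scatter), and the change from methoxy gives an at least 5.5-fold higher number from compound 2 to compound 4 (0.74 log units; beyond the scatter), so the direct fluorinated group separates clearly from both small groups, with each step being a minimum size. The result for compound 4 is a limit and not a number, as is the result for compound 1, so the step between these two compounds cannot be read and the two fluorinated groups cannot be ranked: the limit of > 50000 nM in this assay, at which 2 of the 4 values shown sit.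

The compounds shown do not separate the fluorine atoms from the larger count of heavy atoms in trifluoromethyl, a question that a tert-butyl group or a single chlorine atom at this position would address. They also leave open how an amine or a carboxylic acid on this aromatic carbon would read in this assay.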